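Pyridinylmethyl to dichlorobenzyl on a shared piperidinol core

The compounds below may be only part of what the source reports. "The series", "measured", "known", "first", "only" and "open" are said of these compounds alone.

Compound 1 `O=c1c2cnn(-c3ccc(F)cc3)c2ncn1CC1(O)CCN(Cc2cccnc2)CC1` carries a (pyridin-3-yl)methyl group on the ring amine nitrogen of a shared core, but in an assay on Sf21 cells for inhibition of ubiquitin carboxyl-terminal hydrolase 7 (Homo sapiens), read by spectrophotometry, with stated times of 30 min and 2 h (on this read-out lower numbers stand for stronger inhibition and higher numbers for weaker inhibition), compound 1 gives "not determined" (no result reported). Compound 2 `O=c1c2cnn(-c3ccc(F)cc3)c2ncn1CC1(O)CCN(Cc2cc(F)cc(F)c2)CC1` belongs to the same series, and in this assay compound 2 likewise gives "not determined" (no result reported). Within the data shown here, the only number in the set comes from compound 3 `O=c1c2cnn(-c3ccc(F)cc3)c2ncn1CC1(O)CCN(Cc2ccc(F)cc2Cl)CC1`, which in this assay gives 1600 nM. Among the measured compounds shown here, compound 1 therefore stands without a value of its own, and no step between measured compounds can be drawn from what is known.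

Compound 4 `O=c1c2cnn(-c3ccc(F)cc3)c2ncn1CC1(O)CCN(Cc2ccc(Cl)cc2Cl)CC1` differs from compound 1 in one place: 2,4-dichlorophenyl in place of pyridin-3-yl on a saturated chain carbon bound to an amine nitrogen in a ring. Since compound 1 has no number, neither the size nor the direction of this step in this assay can be stated from the data; what remains is the closeness of compound 4 to compound 3, whose 2,4-dichlorobenzyl and 2-chloro-4-fluorobenzyl groups are nearly alike.

On that ground compound 4 is expected to give about 1300 nM in this assay, with a plausible range from 450 nM to 4000 nM, resting on the value of compound 3 1600 nM.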

Compound 4, half-maximal inhibitory concentration: 3300 nM
For compound 4 the middle estimate is 2.5-fold (0.40 log units) below the measured one; low and high end bracket the measured number.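

In this assay, among these compounds, the series now has its first readable step, a 2.1-fold higher number from compound 3 to compound 4 (0.31 log units; beyond the scatter) with chloro in place of fluoro on an aromatic carbon as the only change. This shows that the benzyl group on the ring amine nitrogen does not tolerate every halogen swap equally: a single exchange of one halogen for another moves the number beyond the usual scatter, though only modestly, and here chloro gives the weaker inhibition of the two. No measurement shown here accounts for the direction or the size of this step.

Going by these compounds, compound 1 and compound 2 carry no number, and any step from them cannot be read, so it remains open how pyridin-3-yl compares with a ring of carbon only on the same saturated chain carbon. On these data alone, it is also open whether the trend from fluoro to chloro continues with bromo on that aromatic carbon, and how a methoxy group or an amine would fare there.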